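Trifluoromethyl in place of hydroxy on the aryl ring

The source may report more compounds than this note shows. Statements on the series, on what has been measured and on what is new or still open speak of the compounds shown alone.

Compound 3 `OCCCCC#Cc1ccccc1C#Cc1cccc(O)c1` stands highest of the three measured numbers in a functional assay on SF-295 cells (Homo sapiens) for cytotoxicity; on this read-out higher numbers stand for weaker inhibition of growth and lower numbers for stronger inhibition of growth: it gives 21000 nM, against 7900 nM for compound 2 `COc1cccc(C#Cc2ccccc2C#CCCCCO)c1` and 150 nM for compound 1 `OCCCCC#Cc1ccccc1C#Cc1ccccc1`. Compound 4 `OCCCCC#Cc1ccccc1C#Cc1cccc(C(F)(F)F)c1` carries trifluoromethyl in place of hydroxy on an aromatic carbon. Among the compounds with values here, no measured step concerns trifluoromethyl. The bearing steps are a 53-fold higher number from compound 1 to compound 2 (1.72 log units; beyond the scatter) and a 140-fold higher number from compound 1 to compound 3 (2.15 log units; beyond the scatter), both large, showing that a group on this aromatic carbon weakens the compound strongly, while a 2.7-fold higher number from compound 2 to compound 3 (0.42 log units; beyond the scatter) is modest. Since compound 3 already sits at the weak end, a modest step back toward compound 2 is expected, with the direction uncertain, as a 3.5-fold lower number from compound 3 to compound 4 (0.54 log units; beyond the scatter). For compound 4 the estimate in this assay is 6000 nM, within 1000 nM to 40000 nM.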

Compound 4, concentration for 50% growth inhibition: 16500 nM
For compound 4 the middle estimate is 2.8-fold (0.44 log units) below the measured one; measured number inside the range.
By their numbers in this assay, from the lowest: compound 1; then compound 2; then compounds 4 and 3 (each within the scatter of the next).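

In this assay, the step from hydroxy to trifluoromethyl on this aromatic carbon stays within the scatter (a 1.3-fold lower number from compound 3 to compound 4 (0.10 log units; within the scatter)), although hydroxy has a hydrogen-bond donor and acceptor and trifluoromethyl has neither. The step from methoxy is modest (a 2.1-fold higher number from compound 2 to compound 4 (0.32 log units; beyond the scatter)), while the step from hydrogen is large (a 110-fold higher number from compound 1 to compound 4 (2.04 log units; beyond the scatter)), so compounds 2, 3 and 4 all show numbers far higher than compound 1, and none of the shown compounds goes against this. Nothing available explains this shared loss of growth inhibition.

Going by these compounds, what an amine or a carboxylic acid would give on this aromatic carbon stays open. So does whether any group here can match hydrogen.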